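Methoxy to Difluoromethoxy on the Pyridine-Bearing Aniline Arm

A few compounds are considered here, and "the series" means these few. Any claim that something is new, unique, unknown or untested is made for them only; others in the source may bear on it.

The three measured compounds share one core and differ only in the group on the aromatic nitrogen. In an assay on frontal cortex for displacement of a labelled ligand from corticotropin-releasing factor receptor 1 (Rattus norvegicus) (a lower number here means a stronger inhibitor, a higher number a weaker inhibitor), compound 1 `COC[C@@H](C1CC1)n1cc(Cl)nc(Nc2cc(C)c(OC)nc2C)c1=O` gives 1.1 nM, compound 2 `CC[C@H](C1CC1)n1cc(Cl)nc(Nc2cc(C)c(OC)nc2C)c1=O` gives 0.28 nM, and compound 3 `COc1nc(C)c(Nc2nc(Cl)cn([C@H](C)C3CC3)c2=O)cc1C` gives 1.5 nM. Compound 3 holds the highest of the three numbers; its gap to compound 1 is within the scatter, while a 5.4-fold higher number from compound 2 to compound 3 (0.73 log units; beyond the scatter) lies beyond it. The other steps were a 3.9-fold lower number from compound 1 to compound 2 (0.59 log units; beyond the scatter) and a 1.4-fold higher number from compound 1 to compound 3 (0.13 log units; within the scatter).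

Compound 4 `Cc1cc(Nc2nc(Cl)cn([C@H](C)C3CC3)c2=O)c(C)nc1OC(F)F` departs from compound 3 by difluoromethyl in place of methyl on an oxygen on an aromatic ring. Going by the values given here, none of the measured steps touches this oxygen; all three concern the aromatic nitrogen, so no measured step bears directly on this change, and the data give no ground for expecting a step beyond the scatter in either direction in this assay . The expected step is therefore a 1.3-fold higher number from compound 3 to compound 4 (0.12 log units; within the scatter), and compound 4 is estimated at 2 nM in this assay , with a range from 0.6 nM to 7 nM.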

Compound 4, half-maximal inhibitory concentration: 0.3 nM
The estimate for compound 4 lay 6.7-fold (0.82 log units) above the measured number, outside the stated range (below it).
By their numbers in this assay, from the lowest: compounds 2 and 4 (each within the scatter of the next); then compounds 1 and 3 (each within the scatter of the next).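

Going by these compounds alone, the oxygen on the aromatic ring, which none of the earlier steps touched, proves responsive in this assay: with the 1-cyclopropylethyl group kept on the aromatic nitrogen, difluoromethyl in place of methyl gives a 5.0-fold lower number from compound 3 to compound 4 (0.70 log units; beyond the scatter). The earlier compounds shown here varied only the group on the aromatic nitrogen, so they could not show that a change at this second place moves the number beyond the scatter. Nothing measured here bears on why the number falls with this change.

As far as these compounds go, whether methoxy to difluoromethoxy would have a similar effect with the 1-cyclopropylpropyl group of compound 2 on the aromatic nitrogen remains open. So does the effect of other groups on the same oxygen, such as trifluoromethyl, monofluoromethyl or ethyl, which would show whether the step follows the number of fluorine atoms or the size of the group.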